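Changing the aryl on the sulfonyl sulfur

A few compounds are considered here, and "the series" means these few. Any claim that something is new, unique, unknown or untested is made for them only; others in the source may bear on it.

Three compounds share one core and differ only in a single group on it. Compound 1 `Cc1ccc(S(=O)(=O)c2cnc3ccc(F)cc3c2N2CCC(C)CC2)cc1F` gives 86% in an assay on isolated protein for displacement of a labelled ligand from metabotropic glutamate receptor 5 (Homo sapiens), with a stated time of 60 min, tested at 1 uM; on this read-out higher numbers stand for more inhibition at the one concentration tested (going by the name of the read-out) and lower numbers for less inhibition. Compound 3 `Cc1ccc2ncc(S(=O)(=O)c3ccc(C)c(F)c3)c(N3CCC(C)CC3)c2c1` gives 91% in this assay, and compound 2 `COc1ccc2ncc(S(=O)(=O)c3ccc(C)c(F)c3)c(N3CCC(C)CC3)c2c1` gives 73%. Compound 2 stands lowest of the three: the step of a number 13 percentage points lower from compound 1 to compound 2 (beyond the scatter) is beyond the scatter, as is a number 18 percentage points higher from compound 2 to compound 3 (beyond the scatter), while a number 5 percentage points higher from compound 1 to compound 3 (within the scatter) lies within it.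

Compound 4 `COc1ccc2ncc(S(=O)(=O)c3cc(C)cc(C)c3)c(N3CCC(C)CC3)c2c1` is not yet measured. It differs from compound 2 in 3,5-dimethylphenyl in place of 3-fluoro-4-methylphenyl on a sulfonyl sulfur. Within the data shown here, every measured step changed a fluoro, methoxy or methyl on an aromatic carbon of the shared core; none touched the ring on the sulfonyl sulfur, so no measured step bears directly on this change, and the data give no direction for it. The best guide is therefore compound 2 itself, whose value of 73% serves as the starting point. The expected step of a number 3 percentage points lower from compound 2 to compound 4 (within the scatter) is thus no larger than the scatter, although the range must stay wide to reflect the lack of a matching precedent. Compound 4 is estimated at 70% in this assay, between 45% and 90%.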

Compound 4, a percentage reported as inhibition, at one concentration (the size of the read-out at that concentration, not a potency): 79%
The estimate for compound 4 lay 9 percentage points below the measured number; measured number inside the range.
By their numbers in this assay, from the lowest: compounds 2, 4, 1 and 3 (each within the scatter of the next, the first and the last beyond it).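

Among these compounds, this is the first change made to the ring on the sulfonyl sulfur rather than to the shared core, and in this assay it gives a number 6 percentage points higher from compound 2 to compound 4 (within the scatter). Replacing 3-fluoro-4-methylphenyl with 3,5-dimethylphenyl keeps the count of 8 heavy atoms and swaps one fluorine for one carbon, and this exchange cannot be told apart from no change on this read-out, whereas the swap on the core gives a number 18 percentage points higher from compound 2 to compound 3 (beyond the scatter) and lies beyond the scatter. Nothing available explains the size of this step, so the result stands as an observation only.

One pair on the methoxy-bearing core says little about how much the ring on the sulfonyl sulfur can vary, and a ring carrying an amine or a carboxylic acid in this place remains an open case. As far as these compounds go, it is also open whether 3,5-dimethylphenyl would give a similarly small step on the cores of compound 1 and compound 3, where the numbers stand nearer the top of the scale.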